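Amide aryl swap on the shared core: tolerance notes

The source may hold more compounds than are shown below. What is called first, only, known or untested is meant among the compounds shown, and "the series" means these compounds.

Compound 2 `COc1ccc(-c2cnc(NC(=O)c3ccco3)n2C)cc1` carries a furan-2-yl on the carbonyl carbon of the shared core. In a toxicity assay on THP-1 cells (Homo sapiens) for inhibition (a lower number here means that less compound is tolerated, a higher number that more compound is tolerated), compound 2 gives > 100000 nM, which is a limit of the assay and not a number. The second measured member, compound 1 `Cc1ccccc1-c1cnc(NC(=O)c2ccc(F)cc2)n1C`, also ends at a limit. In this assay compound 1 gives > 50000 nM, again a limit rather than a number. Compound 2 thus stands at the limit of > 100000 nM in this assay, at which 1 of the 2 values shown sits, whereas compound 1 stands at the limit of > 50000 nM in this assay, at which 1 of the 2 values shown sits; neither value separates the two beyond the scatter, and both speak of tolerance across the tested range. The next member, compound 3 `COc1ccc(-c2cnc(NC(=O)c3ccc(Cl)cc3)n2C)cc1`, differs from compound 2 by one change: 4-chlorophenyl in place of furan-2-yl on a carbonyl carbon. For the measured compounds named here, no measured step covers this change. In this assay the step to compound 3 is expected to be none beyond the scatter, a limit being the likely read-out. For compound 3 the estimated half-maximal cytotoxic concentration is 100000 nM, with a range from 30000 nM to 300000 nM. The expected step is a number no higher from compound 2 to compound 3 (the limit leaves the size open).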

Compound 3, half-maximal cytotoxic concentration: > 100000 nM
Compound 3 ended at the assay's limit (the forecaster's own chance of this, stated with the estimate: 70%); the middle value sits exactly at the limit.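

Compound 2 and compound 3 both end at a limit in this assay, and no step between them can be read: the limit of > 100000 nM in this assay, at which 2 of the 3 values shown sit.

The compounds shown leave open where the half-maximal cytotoxic concentration of either compound lies, and whether 4-chlorophenyl in place of furan-2-yl on a carbonyl carbon shifts it at all in this assay.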